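The compounds below may be only part of what the source reports. "The series", "measured", "known", "first", "only" and "open" are said of these compounds alone.

Measured compounds in a functional assay on THP-1 cells (Homo sapiens) for inhibition, read by sulforhodamine B assay, with a stated time of 48 h, tested at 50 uM; a lower number here means less inhibition of growth, a higher number more inhibition of growth at the concentration tested:
Compound 1 `COc1cc(/C=C/C(=O)/C=C/c2ccco2)ccc1OCc1cn(CCCOc2cc(=O)oc3ccccc23)nn1` gives 57%.
Compound 2 `COc1ccccc1/C=C/C(=O)/C=C/c1ccc(OCc2cn(CCCOc3cc(=O)oc4ccccc34)nn2)c(OC)c1` gives 50%.
Compound 3 `COc1cc(/C=C/C(=O)/C=C/c2ccco2)ccc1OCc1cn(CCOc2cc(=O)oc3ccccc23)nn1` gives 78%.

Compound 3 stands highest of the three, beyond the scatter from compound 1 and from compound 2. Compound 4 `COc1ccccc1/C=C/C(=O)/C=C/c1ccc(OCc2cn(CCOc3cc(=O)oc4ccccc34)nn2)c(OC)c1` is not yet measured in this assay. The difference between the cores of compound 3 and compound 1 is not broken down here. From compound 1 to compound 2 the change is 2-methoxyphenyl in place of furan-2-yl on a double-bonded chain carbon bound to a double-bonded chain carbon, and it made a number 7 percentage points lower from compound 1 to compound 2 (within the scatter). From compound 3 to compound 4 the change is 2-methoxyphenyl in place of furan-2-yl on a double-bonded chain carbon bound to a double-bonded chain carbon, the same change at the same place. Within the data shown here, for compound 4 the expected step is a number 7 percentage points lower from compound 3 to compound 4 (within the scatter), of about the size seen in a number 7 percentage points lower from compound 1 to compound 2 (within the scatter), since only that one earlier step is known. Compound 4 is therefore estimated at 71%, between 55% and 85%.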

Compound 4, percent growth inhibition at one concentration: 75%
Beside the measured number, compound 4's estimate is 4 percentage points below it; measured number inside the range.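

In this assay, 2-methoxyphenyl in place of furan-2-yl on a double-bonded chain carbon bound to a double-bonded chain carbon gives a number 3 percentage points lower from compound 3 to compound 4 (within the scatter). The change carries from one core to the other with no detectable difference in its effect: the same change on two cores in this assay, a number 7 percentage points lower (within the scatter) from compound 1 to compound 2 and a number 3 percentage points lower (within the scatter) from compound 3 to compound 4, 4 percentage points apart, within the scatter of two such steps

Among these compounds, both steps lie within the scatter, so the two pairs show only that this swap leaves the number unmoved on these two cores, not that it would do so on any other core or at another concentration.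

The compounds shown leave open what an amine or a carboxylic acid would do in place of furan-2-yl. They also leave open whether a chain longer than that of compound 1 would show the same result with this swap.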